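This account rests on a few compounds, and the source may have more. Where it says the series, first, only, none or still open, it means among the compounds named here.

In an assay on CHO cells for displacement of a labelled ligand from Neuronal acetylcholine receptor; alpha3/alpha6/beta2/beta3 (Homo sapiens), read by scintillation counting (on this read-out higher numbers stand for weaker inhibition and lower numbers for stronger inhibition), compound 1 `CCC(=O)N1CC2CC(C1)N2` gives 190 nM, the second highest of the three numbers recorded. Compound 2 `CC(C)C(=O)N1CC2CC(C1)N2` gives 580 nM, and compound 3 `C[C@H]1C[C@H]1C(=O)N1CC2CC(C1)N2` gives 170 nM. Against those, compound 1 sits within the scatter of compound 3 and has a lower number than compound 2, shown by the step of a 3.1-fold higher number from compound 1 to compound 2 (0.48 log units; beyond the scatter).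

Compound 4 `C[C@H]1C[C@@H]1C(=O)N1CC2CC(C1)N2` differs from compound 1 as follows: 2-methylcyclopropyl in place of ethyl on a carbonyl carbon. The same 2-methylcyclopropyl group appears in compound 3, which differs from compound 4 only in the arrangement of its two defined stereocentres. The measured step that bears most directly on this change is a 1.1-fold lower number from compound 1 to compound 3 (0.05 log units; within the scatter), and the related step of a 3.4-fold lower number from compound 2 to compound 3 (0.53 log units; beyond the scatter) shows that the ring-bearing group held its own against an isopropyl group as well. On that basis compound 4 is expected to land close to compound 1, with an estimated step of a 1.1-fold higher number from compound 1 to compound 4 (0.02 log units; within the scatter), none clearly beyond the scatter in either direction. The estimate for compound 4 in this assay is 200 nM, with a range from 80 nM to 500 nM.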

Compound 4, inhibition constant: 310 nM
Estimate against measurement, compound 4: 1.6-fold (0.19 log units) below; low and high end bracket the measured number.
By their numbers in this assay, from the lowest: compounds 3, 1, 4 and 2 (each within the scatter of the next, the first and the last beyond it).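

Changing the arrangement of the 2-methylcyclopropyl group on the carbonyl carbon leaves the number within the scatter (a 1.8-fold higher number from compound 3 to compound 4 (0.26 log units; within the scatter)), so the compounds shown reveal no clear preference between these two drawn forms. Compound 4 also stays within the scatter of the ethyl amide (a 1.6-fold higher number from compound 1 to compound 4 (0.21 log units; within the scatter)), extending the earlier match between compound 1 and compound 3 to a second drawn form. Unlike compound 3, however, compound 4 cannot be separated from the isopropyl amide (a 1.9-fold lower number from compound 2 to compound 4 (0.27 log units; within the scatter)), so the clear gap seen for compound 3 against compound 2 does not carry over to this form.

As far as these compounds go, whether a longer chain such as butyl, or a cyclobutyl ring, on the carbonyl carbon would move the number beyond the scatter of compound 1 remains open. Any link between configuration and number in compounds 3 and 4 also remains uncertain because of how the pair is drawn: the fact that one of compounds 3 and 4 is drawn with a defined configuration and the other without, at the place where they differ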